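Methyl on the chain carbon beside a ring amine

The source may report more compounds than this note shows. Statements on the series, on what has been measured and on what is new or still open speak of the compounds shown alone.

Compound 1 `CCN1CC[C@@]2(OC)OC(N)=C(C#N)[C@@H](c3ccccc3)[C@@H]2C1` gives 23400 nM in a functional assay on trachea (Cavia porcellus); on this read-out lower numbers stand for stronger inhibition and higher numbers for weaker inhibition. Compound 2 `CCCN1CC[C@@]2(OC)OC(N)=C(C#N)[C@@H](c3ccccc3)[C@@H]2C1` gives 20700 nM. Compound 3 `CO[C@@]12CCN(C)C[C@H]1[C@H](c1ccc(C)cc1)C(C#N)=C(N)O2` gives 13200 nM.

Compound 4 `CCN1CC[C@@]2(OC)OC(N)=C(C#N)[C@@H](c3ccc(C)cc3)[C@@H]2C1` is not yet measured. It differs from compound 3 by methyl in place of hydrogen on a saturated chain carbon bound to an amine nitrogen in a ring. The measured pair shows a change of the same kind, (methyl in place of hydrogen on a saturated chain carbon, two bonds along the chain from an amine nitrogen in a ring), with the step of a 1.1-fold lower number from compound 1 to compound 2 (0.05 log units; within the scatter); the place differs, since there the methyl enters two bonds along the chain from the amine nitrogen, here on the chain carbon bound to it. The difference between the cores of compound 1 and compound 3 is not broken down here; the two values lie within the scatter of each other.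

For compound 4 the expected step is a 1.1-fold lower number from compound 3 to compound 4 (0.04 log units; within the scatter), because the matching step reads a 1.1-fold lower number from compound 1 to compound 2 (0.05 log units; within the scatter). Compound 4 is therefore estimated at 12000 nM, with a range from 6000 nM to 25000 nM.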

Compound 4, half-maximal inhibitory concentration: 16800 nM
Compound 4: the middle estimate sits 1.4-fold (0.15 log units) below what was measured; measured number inside the range.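

In this assay, methyl in place of hydrogen on a saturated chain carbon bound to an amine nitrogen in a ring gives a 1.3-fold higher number from compound 3 to compound 4 (0.10 log units; within the scatter), and methyl in place of hydrogen on an aromatic carbon gives a 1.4-fold lower number from compound 1 to compound 4 (0.14 log units; within the scatter). Set beside the earlier step, the chain change reads alike on the two cores: the same change on two cores in this assay, a 1.1-fold lower number (0.05 log units; within the scatter) from compound 1 to compound 2 and a 1.3-fold higher number (0.10 log units; within the scatter) from compound 3 to compound 4, 1.4-fold (0.16 log units) apart, within the scatter of two such steps. This shows no readable effect of the added chain methyl on either core, but it does not show that an effect carries over, as neither step exceeds the scatter and the methyl enters at a different place in each pair.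

Open, going by these compounds, is whether a longer chain, such as butyl, on the amine nitrogen would give a step beyond the scatter. Also open, on these data alone, is what chlorine or methoxy would do on that aromatic carbon.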